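The source may report more compounds than this note shows. Statements on the series, on what has been measured and on what is new or still open speak of the compounds shown alone.

Working notes on the series. Compound 1 `O=C(CSc1nc(Nc2ccccc2)c2ccccc2n1)Nc1ccccc1F`, compound 2 `O=C(CSc1nc(Nc2ccccc2)c2ccccc2n1)Nc1ccccc1Br` and compound 3 `CCc1cccc(NC(=O)CSc2nc(Nc3ccccc3)c3ccccc3n2)c1` share one core and differ only in the aryl on the amide nitrogen. In a functional assay on MDA-MB-231 cells (Homo sapiens) for inhibition, read by MTT assay, with a stated time of 72 h (on this read-out lower numbers stand for stronger inhibition and higher numbers for weaker inhibition), compound 1 gives only a limit, > 50000 nM, which is the limit of > 50000 nM in this assay, at which 1 of the 3 values shown sits. In this assay compound 2 gives 14100 nM. In this assay compound 3 gives 12400 nM; compound 3 and compound 2 sit within the scatter of each other, so the two are not separated, and compound 1 supplies no number. The measured steps read an at least 3.5-fold lower number from compound 1 to compound 2 (0.54 log units; beyond the scatter), an at least 4.0-fold lower number from compound 1 to compound 3 (0.60 log units; beyond the scatter) and a 1.1-fold lower number from compound 2 to compound 3 (0.06 log units; within the scatter).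

Compound 4 `O=C(CSc1nc(Nc2ccccc2)c2ccccc2n1)Nc1ccc(Br)cc1` is not yet measured. The change from compound 3 is 4-bromophenyl in place of 3-ethylphenyl on an amide-type nitrogen. Bearing on it are the aryl exchanges on the amide nitrogen, a 1.1-fold lower number from compound 2 to compound 3 (0.06 log units; within the scatter), which is within the scatter, and an at least 4.0-fold lower number from compound 1 to compound 3 (0.60 log units; beyond the scatter), which rests on a limit, together with the halogen exchange an at least 3.5-fold lower number from compound 1 to compound 2 (0.54 log units; beyond the scatter). Within the data shown here, no measured step involves a 4-bromophenyl. A step within the scatter, or at most a small rise, is expected: a 1.1-fold higher number from compound 3 to compound 4 (0.05 log units; within the scatter). Compound 4 is estimated at 14000 nM, between 6000 nM and 40000 nM.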

Compound 4, half-maximal inhibitory concentration: 11500 nM
Estimate against measurement, compound 4: 1.2-fold (0.09 log units) above, within the range that was stated.
By their numbers in this assay, from the lowest: compounds 4, 3 and 2 (each within the scatter of the next). At a limit, above all of these: compound 1.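

Among these compounds, the first pair of bromophenyl groups on the amide-type nitrogen gives a 1.2-fold lower number from compound 2 to compound 4 (0.09 log units; within the scatter), and the exchange of 3-ethylphenyl for 4-bromophenyl gives a 1.1-fold lower number from compound 3 to compound 4 (0.03 log units; within the scatter), so neither the place of the bromine nor this change of aryl group separates the compounds in this assay. Against the 2-fluorophenyl group, the reading is an at least 4.3-fold lower number from compound 1 to compound 4 (0.63 log units; beyond the scatter), which gives a bound and not a measured size of step. Compound 1 remains a limit: the limit of > 50000 nM in this assay, at which 1 of the 4 values shown sits.

The compounds shown leave open whether the number for compound 1 belongs to the fluorine itself or to its place, which a 4-fluorophenyl group on the same nitrogen would address. They also leave open whether an amine or a carboxylic acid on this aryl ring would move the number beyond the scatter.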